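A few compounds are considered here, and "the series" means these few. Any claim that something is new, unique, unknown or untested is made for them only; others in the source may bear on it.

Measured compounds in a functional assay on HEK293 cells for agonist activity at G-protein coupled receptor 39 (Homo sapiens), read by scintillation proximity assay and inositol phosphate accumulation, with a stated time of 75 min; a higher number here means that more compound is needed for the effect, a lower number that less compound is needed:
compound 1 `Cc1nn(-c2ncnc3nc[nH]c23)c2c1C(OC1CCCC1)CC(=O)N2` — compound 1 gives 62 nM
compound 2 `Cc1nn(-c2ncnc3nc[nH]c23)c2c1C(OCc1ccccc1F)CC(=O)N2` — compound 2 gives 78 nM
compound 3 `Cc1nn(-c2ncnc3nc[nH]c23)c2c1C(OCc1ccc(F)cc1)CC(=O)N2` — compound 3 gives 126 nM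

Compound 3 has the highest number of the three. The nearer step is a 1.6-fold higher number from compound 2 to compound 3 (0.21 log units; within the scatter), while the further step is a 2.0-fold higher number from compound 1 to compound 3 (0.31 log units; beyond the scatter), a modest but real difference. Compound 4 `COc1ccc(CCOC2CC(=O)Nc3c2c(C)nn3-c2ncnc3nc[nH]c23)cc1` has not yet been measured. It differs from compound 3 in one place: 4-methoxybenzyl in place of 4-fluorophenyl on a saturated chain carbon bound to an oxygen on a saturated carbon; cut one bond further out, the same change reads 4-fluorobenzyl to 2-(4-methoxyphenyl)ethyl.

The measured steps only partly bear on this. The step of a 1.3-fold higher number from compound 1 to compound 2 (0.10 log units; within the scatter) and the step of a 2.0-fold higher number from compound 1 to compound 3 (0.31 log units; beyond the scatter) show that swapping the group on this oxygen shifts the number little to modestly, and a 1.6-fold higher number from compound 2 to compound 3 (0.21 log units; within the scatter) shows that moving a fluorine on the ring stays within the scatter. For the measured compounds named here, no measured step covers a methoxy or a longer chain, so the direction is uncertain. Compound 4 is therefore expected to land near compound 3, with the estimated step of a 1.2-fold higher number from compound 3 to compound 4 (0.08 log units; within the scatter). The expected value for compound 4 is 150 nM, with a range from 50 nM to 450 nM.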

Compound 4, half-maximal effective concentration: 70 nM
Compound 4: middle estimate off by 2.1-fold (0.33 log units), on the high side, within the range that was stated.
By their numbers in this assay, from the lowest: compounds 1, 4, 2 and 3 (each within the scatter of the next, the first and the last beyond it).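

In this assay, the oxygen of the shared core carries 2-(4-methoxyphenyl)ethyl with no step beyond the usual scatter, whether measured against 4-fluorobenzyl (a 1.8-fold lower number from compound 3 to compound 4 (0.26 log units; within the scatter)), 2-fluorobenzyl (a 1.1-fold lower number from compound 2 to compound 4 (0.05 log units; within the scatter)) or cyclopentyl (a 1.1-fold higher number from compound 1 to compound 4 (0.05 log units; within the scatter)). For the compounds shown here, this position therefore accepts a longer chain and a methoxy on the ring, neither of which appeared in the earlier compounds, and the number stays close to those of the benzyl and cyclopentyl ethers. No available evidence explains this result.

As far as these compounds go, the methoxy and the longer chain arrive together in compound 4, so their separate contributions remain unknown. Also open, from the compounds shown here alone, is how a group carrying an amine or a carboxylic acid would read out on this oxygen in this assay.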